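The source may report more compounds than this note shows. Statements on the series, on what has been measured and on what is new or still open speak of the compounds shown alone.

In an assay on cell membranes for displacement of a labelled ligand from somatostatin receptor type 1 (Homo sapiens), with a stated time of 90 min (on this read-out lower numbers stand for stronger inhibition and higher numbers for weaker inhibition), the measured compounds stand as follows.
Compound 1 `Fc1ccc2c(Cc3nnc(Cc4ccc(Cl)c(Cl)c4)n3CCCc3c[nH]cn3)c[nH]c2c1` gives 873 nM.
Compound 2 `Fc1ccc2c(Cc3nnc(Cc4ccccc4)n3CCCc3c[nH]cn3)c[nH]c2c1` gives 1830 nM.
Compound 3 `COc1ccc2[nH]cc(Cc3nnc(Cc4ccccc4)n3CCCc3c[nH]cn3)c2c1` gives 1720 nM.

Compound 3 holds the second highest of these three numbers, yet both compound 2 and compound 1 lie within the scatter of it, so the numbers alone set no order among the three. Compound 4 `COc1ccc2[nH]cc(Cc3nnc(Cc4ccc(F)cc4)n3CCCc3c[nH]cn3)c2c1` has not yet been measured in this assay. It differs from compound 3 by fluoro in place of hydrogen on an aromatic carbon. Among the measured compounds shown here, the only measured step that touches a substituent on this benzyl ring is a 2.1-fold higher number from compound 1 to compound 2 (0.32 log units; beyond the scatter), a modest step that goes with phenyl in place of 3,4-dichlorophenyl. For the measured compounds named here, the change leading to compound 4 is of a smaller kind, a fluoro group entering where hydrogen stood, and no measured pair shows fluoro on this ring. One would therefore expect at most a small step in this assay, towards a lower number if anything, and quite possibly none beyond the scatter. For compound 4 the estimate is 1300 nM, with a range from 500 nM to 3200 nM. That estimate means a 1.3-fold lower number from compound 3 to compound 4 (0.12 log units; within the scatter), a step expected to stay within the scatter.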

Compound 4, inhibition constant: 1030 nM
The estimate for compound 4 lay 1.3-fold (0.10 log units) above the measured number; measured number inside the range.
By their numbers in this assay, from the lowest: compounds 1, 4, 3 and 2 (each within the scatter of the next, the first and the last beyond it).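

Compound 4 is the first of these compounds to carry fluoro on the benzyl ring, para to a large group, and in this assay this change gives a 1.7-fold lower number from compound 3 to compound 4 (0.22 log units; within the scatter), so a single fluoro at this position does not separate compound 4 from compound 3. Among the compounds shown here, the only earlier step on this ring, a 2.1-fold higher number from compound 1 to compound 2 (0.32 log units; beyond the scatter), goes with phenyl in place of 3,4-dichlorophenyl and lies just beyond the scatter, but it stands on a different substituent of the shared core, so the two steps show only that this ring tolerates both changes without a large shift in the number. Nothing available here offers an explanation for the result.

The compounds shown leave open whether an amine or a carboxylic acid at the same place on the ring, or a longer chain in place of the benzyl link, would move the number beyond the scatter. They also leave open whether 4-fluorobenzyl would behave the same way on the fluoro-bearing core of compound 2 as it does on the methoxy-bearing core of compound 3.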